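The source may hold more compounds than are shown below. What is called first, only, known or untested is meant among the compounds shown, and "the series" means these compounds.

Measured compounds:
compound 1 `CCCCCCCCNc1nc(SCc2ccc(C(F)(F)F)cc2)nc2ccccc12` with 22300 nM
compound 2 `FC(F)(F)c1ccc(CSc2nc(Nc3cccc(Br)c3)c3ccccc3n2)cc1` with 22100 nM
compound 3 `COc1ccc(Nc2nc(SCc3ccc(C(F)(F)F)cc3)nc3ccccc23)cc1` with 15700 nM

All three numbers come from a functional assay on MDA-MB-231 cells (Homo sapiens) for cytotoxicity, read by MTT assay, with a stated time of 72 h; on this read-out lower numbers stand for stronger inhibition and higher numbers for weaker inhibition. Compound 1 gives the highest of the three, but its distance to the others is small: the step of a 1.0-fold lower number from compound 1 to compound 2 (0.00 log units; within the scatter) and the step of a 1.4-fold lower number from compound 1 to compound 3 (0.15 log units; within the scatter) both sit within the scatter, as does the step of a 1.4-fold lower number from compound 2 to compound 3 (0.15 log units; within the scatter). For the measured compounds named here, nothing among the measured compounds separates the three substituents on the nitrogen of the shared core from one another.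

Compound 4 `COc1ccc(Nc2nc(SCc3ccc(C(F)(F)F)cc3)nc3ccccc23)c(OC)c1` is not yet measured. Compared with compound 1 it carries 2,4-dimethoxyphenyl in place of octyl on a nitrogen on an aromatic ring. The measured steps that bear on this change are those from octyl to an aryl group on the same nitrogen: a 1.4-fold lower number from compound 1 to compound 3 (0.15 log units; within the scatter), which brings in 4-methoxyphenyl, and a 1.0-fold lower number from compound 1 to compound 2 (0.00 log units; within the scatter), which brings in 3-bromophenyl. Both are within the scatter, so the replacement of octyl by an aryl group on this nitrogen has not moved the read-out beyond noise in this series. Going by the values given here, the second methoxy group in compound 4 has no measured counterpart here, so no step beyond the scatter is expected in this assay for it either. Compound 4 is therefore expected to give about 15000 nM, within 6000 nM to 40000 nM, a step of a 1.5-fold lower number from compound 1 to compound 4 (0.17 log units; within the scatter) that is estimated to stay close to compound 3.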

Compound 4, half-maximal inhibitory concentration: > 50000 nM
Compound 4: only a limit was reported; the forecaster's own chance of this, stated with the estimate: 10%; at least 3.3-fold (0.52 log units) between middle value and limit.
By their numbers in this assay, from the lowest: compounds 3, 2 and 1 (each within the scatter of the next). At a limit, above all of these: compound 4.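

Compound 4 stands at a limit, not at a number, in this assay, so the steps to it give only minimum sizes: the limit of > 50000 nM in this assay, at which 1 of the 4 values shown sits.

The substituent on this nitrogen, which had shown no separation so far, now does: adding one methoxy to the aryl group gives an at least 3.1-fold higher number from compound 3 to compound 4 (0.50 log units; beyond the scatter), and this single change on the aryl group, not the replacement of octyl by an aryl group as such, yields the first steps of the series beyond the scatter. The 2,4-dimethoxyphenyl group is also set apart from the other two substituents, with an at least 2.2-fold higher number from compound 1 to compound 4 (0.35 log units; beyond the scatter) and an at least 2.2-fold higher number from compound 2 to compound 4 (0.35 log units; beyond the scatter), although octyl, 3-bromophenyl and 4-methoxyphenyl remain within the scatter of one another.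

The compounds shown leave open whether a different group in place of the added methoxy, such as a hydroxyl, a fluorine or an amine, would also give a higher number, and how far the true value of compound 4 lies beyond its limit. They also leave open how a shorter chain or a benzyl group on this nitrogen would compare with octyl.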